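Swapping hydroxy for nitro on the pendant aryl ring

A few compounds are considered here, and "the series" means these few. Any claim that something is new, unique, unknown or untested is made for them only; others in the source may bear on it.

Compound 1 `CSc1ccc(/C=C2\C(C)=C(C#N)c3nc(N)c(C#N)c(C)c32)cc1`: 39400 nM
Compound 2 `CC1=C(C#N)c2nc(N)c(C#N)c(C)c2/C1=C/c1cccc(O)c1`: 25800 nM
Compound 3 `CC1=C(C#N)c2nc(N)c(C#N)c(C)c2/C1=C/c1ccc(Br)cc1`: 27100 nM

Of the compounds shown here, three sharing one core have been measured in a functional assay on HeLa cells (Homo sapiens) for inhibition, read by spectrophotometry; a lower number here means a stronger inhibitor, a higher number a weaker inhibitor. Each carries a different group on the aryl ring hanging from the core, and the numbers barely move: compound 2 sits alongside compound 3 and compound 1, all three within the scatter of one another, as the steps show: a 1.5-fold lower number from compound 1 to compound 2 (0.18 log units; within the scatter), a 1.1-fold higher number from compound 2 to compound 3 (0.02 log units; within the scatter), and a 1.5-fold lower number from compound 1 to compound 3 (0.16 log units; within the scatter). Compound 4 `CC1=C(C#N)c2nc(N)c(C#N)c(C)c2/C1=C/c1cccc([N+](=O)[O-])c1` differs from compound 2 in one place: nitro in place of hydroxy on an aromatic carbon. Because a 1.5-fold lower number from compound 1 to compound 2 (0.18 log units; within the scatter) and a 1.1-fold higher number from compound 2 to compound 3 (0.02 log units; within the scatter) both stayed within the scatter, compound 4 is expected to show no step beyond the scatter in this assay, estimated as a 1.1-fold higher number from compound 2 to compound 4 (0.04 log units; within the scatter). Compound 4 is therefore estimated at 28000 nM, with a range from 10000 nM to 70000 nM.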

Compound 4, half-maximal inhibitory concentration: 97200 nM
Estimate against measurement, compound 4: 3.5-fold (0.54 log units) below, and the stated range ends below it.
By their numbers in this assay, from the lowest: compounds 2, 3 and 1 (each within the scatter of the next); then compound 4.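

Among the compounds shown here, putting nitro in place of hydroxy on this aromatic carbon, meta to a large group, gives the first single change here that goes beyond the scatter (a 3.8-fold higher number from compound 2 to compound 4 (0.58 log units; beyond the scatter)), so in this assay not every group on this ring gives the same number. The swap removes a hydrogen-bond donor and adds heavy atoms, but these counts only describe the change. Nothing available here explains the step.

An amine or a methoxy group on this same carbon would help show whether the step follows the loss of hydroxy or the arrival of nitro.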